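From a Heptyloxy Chain to a Chloro Group

A few compounds are considered here, and "the series" means these few. Any claim that something is new, unique, unknown or untested is made for them only; others in the source may bear on it.

Compound 1 `O=C1OC[C@H](Cc2ccccc2)[C@H]1Cc1ccccc1Cl` gives 37000 nM
Compound 2 `O=C1OC[C@H](Cc2ccccc2)[C@H]1Cc1ccc(O)cc1` gives 88000 nM
Compound 3 `CCCCCCCOc1ccc(C[C@H]2C(=O)OC[C@@H]2Cc2ccccc2)cc1` gives > 100000 nM, which is a limit and not a number

All of these values come from a functional assay on HL-60 cells (Homo sapiens) for cytotoxicity, read by WST assay, with a stated time of 48 h; a lower number here means that less compound is needed, a higher number that more compound is needed for the effect. As far as these compounds go, compound 3 stands at the limit of > 100000 nM in this assay, at which 1 of the 3 values shown sits, so its true position remains open. Compound 4 `O=C1OC[C@H](Cc2ccccc2)[C@H]1Cc1ccc(Cl)cc1` keeps the shared core but has chloro in place of heptyloxy on an aromatic carbon, para to a large group: chloro in place of heptyloxy on an aromatic carbon.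

Among the compounds with values here, two measured steps bear on this change. Placing heptyl on the oxygen of compound 2 gave an at least 1.1-fold higher number from compound 2 to compound 3 (0.05 log units; that floor lies within the scatter), so this step sets no firm size for the chain. The other step, a 2.4-fold higher number from compound 1 to compound 2 (0.38 log units; beyond the scatter), swaps 2-chlorophenyl for 4-hydroxyphenyl and is modest. The closest guide is the other chlorinated compound, compound 1, at 37000 nM. A lower number is therefore expected in this assay, with an estimated step of an at least 2.2-fold lower number from compound 3 to compound 4 (0.34 log units; beyond the scatter). For compound 4, the expected value is 45000 nM, with an estimated range from 18000 nM to 100000 nM.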

Compound 4, half-maximal effective concentration: 36000 nM
Estimate against measurement, compound 4: 1.3-fold (0.10 log units) above, and the stated range covers the measured number.
By their numbers in this assay, from the lowest: compounds 4 and 1 (each within the scatter of the next); then compound 2. At a limit, above all of these: compound 3.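

Compound 3, with its heptyloxy chain, gives a limit and not a number: (the limit of > 100000 nM in this assay, at which 1 of the 4 values shown sits). In this assay chloro on this aromatic carbon reads lower than either oxygen-linked group, both against heptyloxy (an at least 2.7-fold lower number from compound 3 to compound 4 (0.44 log units; beyond the scatter)) and against hydroxy (a 2.4-fold lower number from compound 2 to compound 4 (0.39 log units; beyond the scatter)), though the first of these is only a floor on the true step. Where the chlorine sits on the phenyl ring makes no visible difference, since 4-chlorophenyl and 2-chlorophenyl stay within the scatter of each other (a 1.0-fold lower number from compound 1 to compound 4 (0.01 log units; within the scatter)).

As far as these compounds go, the true size of the heptyloxy step stays open, and so does how short a chain would have to be to give a measurable number. From the compounds shown here alone, whether fluoro, methoxy, an amine or a carboxylic acid on this carbon would read like chloro or like hydroxy also remains unknown.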